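This account rests on a few compounds, and the source may have more. Where it says the series, first, only, none or still open, it means among the compounds named here.

Compound 1 `Cn1c(-c2ccc(NC(=O)CN3CCCC3)cc2)nc2cc(C(F)(F)F)ccc21`: > 100000 nM. Compound 2 `O=[N+]([O-])c1ccc(-c2nc3cc(C(F)(F)F)ccc3[nH]2)c([N+](=O)[O-])c1`: 25000 nM.

In an ADME assay on Vero cells (Chlorocebus sabaeus) for cytotoxicity (on this read-out lower numbers stand for higher toxicity in this test and higher numbers for lower toxicity in this test), the value of compound 1 is a limit, not a number: it sits at the limit of > 100000 nM in this assay, at which 1 of the 2 values shown sits. Compound 3 `CCC(=O)Nc1ccc(-c2nc3cc(C(F)(F)F)ccc3n2C)cc1` differs from compound 1 in one place: methyl in place of pyrrolidin-1-yl on a saturated chain carbon bound to a carbonyl carbon. For the measured compounds named here, no measured pair covers this change, so its effect is not known from the data. Going by the values given here, compound 1 and compound 2 differ in several places, and their two values show only that compound 2 gives a number while compound 1 does not. Compound 3 is expected to stay close to compound 1, with an expected step of a number no higher from compound 1 to compound 3 (the limit leaves the size open) not beyond the usual scatter in either direction. Compound 3 is estimated at 100000 nM, between 30000 nM and 300000 nM.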

Compound 3, half-maximal cytotoxic concentration: > 100000 nM
Compound 3 ended at the assay's limit (the forecaster's own chance of this, stated with the estimate: 60%); the middle value lies on the limit itself.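

No step from compound 1 to compound 3 can be read, because both results are limits, not numbers: the limit of > 100000 nM in this assay, at which 2 of the 3 values shown sit.

Going by these compounds, whether methyl in place of pyrrolidin-1-yl changes toxicity at all, and by how much, stays open.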